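Solubility of a trifluoromethoxy analogue from three limit values

A few compounds are considered here, and "the series" means these few. Any claim that something is new, unique, unknown or untested is made for them only; others in the source may bear on it.

Measured so far:
compound 1 `CNC(=O)c1cc(Oc2ccc3nc(Nc4cccc(C(C)(C)C)c4)ncc3c2)ccn1`: < 1000 nM
compound 2 `CNC(=O)c1cc(Oc2ccc3nc(Nc4cccc(OC(F)(F)F)c4)ncc3c2)ccn1`: < 1000 nM
compound 3 `CNC(=O)c1cc(Oc2ccc3nc(Nc4ccc(OC)cc4)ncc3c2)ccn1`: < 1000 nM

In a physicochemical assay for solubility, at pH 7 (a higher number here means a more soluble compound, a lower number a less soluble compound), compound 1 gives only a limit, < 1000 nM. Compound 2 likewise gives only a limit. Compound 3 also gives only a limit. The steps a step that the two limits leave unreadable from compound 1 to compound 2 and a step that the two limits leave unreadable from compound 1 to compound 3 and a step that the two limits leave unreadable from compound 2 to compound 3 therefore cannot be sized, since (the limit of < 1000 nM in this assay, at which 3 of the 3 values shown sit).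

Compound 4 `CNC(=O)c1cc(Oc2ccc3nc(Nc4ccc(OC(F)(F)F)cc4)ncc3c2)ccn1` is not yet measured. The change is 4-(trifluoromethoxy)phenyl in place of 3-(tert-butyl)phenyl on a nitrogen on an aromatic ring. No measured step can be read in this assay, so no direction can be expected beyond the scatter. Compound 4 is estimated at 500 nM, in the range 100 nM to 1500 nM, an expected step that the limit leaves unreadable from compound 1 to compound 4, most likely again reported as a limit.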

Compound 4, solubility: < 1000 nM
Compound 4 ended at the assay's limit; the forecaster's own chance of this, stated with the estimate: 80%; the middle value lies beyond the limit too.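

Compound 4 gives only a limit in this assay, as do compound 1, compound 2 and compound 3, so none of its steps to them can be read: the limit of < 1000 nM in this assay, at which 4 of the 4 values shown sit.

Going by these compounds, how these four compounds rank in this assay, and whether any of these group changes shifts solubility at all, remains open.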